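The compounds below may be only part of what the source reports. "The series", "measured", "known", "first", "only" and "open" are said of these compounds alone.

Of the compounds shown here, two have been measured in a functional assay on HCT-15 cells (Homo sapiens) for cytotoxicity; a higher number here means a weaker inhibitor, a lower number a stronger inhibitor. Compound 1 `Cc1nn(C)c(N2CCCC2)c1/C=N/OCc1ccc(C(=O)OC(C)(C)C)cc1` gives 0.1 ug/mL in this assay, while compound 2 `Cc1nn(C)c(-n2cccn2)c1/C=N/OCc1ccc(C(=O)OC(C)(C)C)cc1` gives 3.63 ug/mL. For the measured compounds named here, compound 2 therefore stands at the highest number of the two, the weaker of the pair, and its only neighbour is compound 1. Going by the values given here, the single step seen so far, a 36-fold higher number from compound 1 to compound 2 (1.56 log units; beyond the scatter), shows that the group on this aromatic carbon of the shared core has a strong effect on the number. Compound 3 `Cc1nn(C)c(Sc2ccccc2)c1/C=N/OCc1ccc(C(=O)OC(C)(C)C)cc1` differs from compound 2 at the same place: phenylsulfanyl in place of 1H-pyrazol-1-yl on an aromatic carbon. Among the compounds with values here, no measured step involves phenylsulfanyl, so the direction of the change cannot be read from the data; the one step that bears on it was large, so a large step in either direction is plausible. Because a 36-fold higher number from compound 1 to compound 2 (1.56 log units; beyond the scatter) shows that swapping the group at this place can move the number by a wide margin, compound 3 is expected to land somewhere between the two measured numbers, with an expected step of a 3.6-fold lower number from compound 2 to compound 3 (0.56 log units; beyond the scatter). The estimate for compound 3 in this assay is 1 ug/mL, with a range from 0.1 ug/mL to 10 ug/mL.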

Compound 3, half-maximal inhibitory concentration: 0.26 ug/mL
Beside the measured number, compound 3's estimate is 3.8-fold (0.59 log units) above it; the range from low to high includes it.
By their numbers in this assay, from the lowest: compound 1; then compound 3; then compound 2.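

In this assay, the change to phenylsulfanyl gives a 14-fold lower number from compound 2 to compound 3 (1.14 log units; beyond the scatter), so replacing pyrrolidin-1-yl at this position does not always cost as much as 1H-pyrazol-1-yl did. Phenylsulfanyl also carries an aromatic ring, so having an aromatic ring in the group on this carbon does not by itself go with a high number, although with only three compounds this is one counterexample and not a rule. Measured against the pyrrolidin-1-yl group, phenylsulfanyl gives a 2.6-fold higher number from compound 1 to compound 3 (0.41 log units; beyond the scatter), a modest but real gap that leaves compound 1 with the lowest number of the three, and no supporting data are available to explain why these groups differ.

The compounds shown leave open which feature of the group sets the number, since phenylsulfanyl differs from 1H-pyrazol-1-yl in its ring, its linking atom and its size all at once. A phenoxy group, with oxygen in place of the sulfur, or an open-chain dimethylamino group at this position would help to separate these features.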